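Cyclopropane dicarboxamide anilides: aryl swap on the amide

This account rests on a few compounds, and the source may have more. Where it says the series, first, only, none or still open, it means among the compounds named here.

Compound 1 `CN(C)C(=O)c1cc2cnc(Nc3ccc(NC(=O)C4(C(=O)Nc5ccc(Cl)cc5)CC4)cc3)nc2n1C1CCCC1` is the reference of this set. In a functional assay on A549 cells (Homo sapiens) for inhibition, read by CCK-8 assay, with a stated time of 72 h, tested at 1 uM (a higher number here means more inhibition of growth at the concentration tested, a lower number less inhibition of growth), compound 1 gives 24.7%, the highest of the three measured numbers, with both other compounds beyond the scatter below it. Compound 2 `CN(C)C(=O)c1cc2cnc(Nc3ccc(NC(=O)C4(C(=O)Nc5ccc(Br)cc5)CC4)cc3)nc2n1C1CCCC1` gives -6.6% and compound 3 `CN(C)C(=O)c1cc2cnc(Nc3ccc(NC(=O)C4(C(=O)Nc5ccc(Cl)c(C(F)(F)F)c5)CC4)cc3)nc2n1C1CCCC1` gives 1.1%. The two steps away from compound 1 both point down: a number 31.3 percentage points lower from compound 1 to compound 2 (beyond the scatter) and a number 23.6 percentage points lower from compound 1 to compound 3 (beyond the scatter). Between the two weaker compounds, a number 7.7 percentage points higher from compound 2 to compound 3 (within the scatter), so they cannot be ordered.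

Compound 4 `CN(C)C(=O)c1cc2cnc(Nc3ccc(NC(=O)C4(C(=O)Nc5cccc(C(F)(F)F)c5)CC4)cc3)nc2n1C1CCCC1` is not yet measured. Relative to compound 1 the change is 3-(trifluoromethyl)phenyl in place of 4-chlorophenyl on an amide-type nitrogen. Among the measured compounds shown here, two measured steps bear on it. Adding a trifluoromethyl to the aryl ring on that amide-type nitrogen lowered growth inhibition, as did exchanging the halogen; every change so far to the 4-chlorophenyl group has cost activity, and compound 4 both removes the chloro and introduces a trifluoromethyl. A downward step is therefore expected, of a size comparable to the measured ones. Because a number 23.6 percentage points lower from compound 1 to compound 3 (beyond the scatter) already fell beyond the scatter, compound 4 is expected to give 4%, with a range of -14% to 24%. The expected step is a number 20.7 percentage points lower from compound 1 to compound 4 (beyond the scatter), downward and beyond the scatter.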

Compound 4, percent growth inhibition at one concentration: 15.7%
Compound 4: the middle estimate sits 11.7 percentage points below what was measured, and the stated range covers the measured number.
By their numbers in this assay, from the lowest: compounds 2 and 3 (each within the scatter of the next); then compounds 4 and 1 (each within the scatter of the next).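

Working notes on the aryl group on the amide-type nitrogen: in this assay, 3-(trifluoromethyl)phenyl in place of 4-chlorophenyl is the first change at this position that stays within the scatter of the reference (a number 9 percentage points lower from compound 1 to compound 4 (within the scatter)), so this position does not lose growth inhibition with every change. The trifluoromethyl group therefore does not go with a loss on its own: the step that removes only the chloro (a number 14.6 percentage points higher from compound 3 to compound 4 (beyond the scatter)) shows that the low number of compound 3 belongs to chloro and trifluoromethyl present together on the ring, not to trifluoromethyl alone. The aryl groups also separate without any shared direction, since 3-(trifluoromethyl)phenyl in place of 4-bromophenyl also gives a step beyond the scatter (a number 22.3 percentage points higher from compound 2 to compound 4 (beyond the scatter)), which sets compound 2 and compound 3 apart from compound 1 and compound 4 as two distinct levels.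

Still open, going by these compounds, is what unsubstituted phenyl, or a phenyl carrying an amine or a carboxylic acid, would give on this nitrogen, and so whether chloro or trifluoromethyl contributes anything over hydrogen. No measurement at hand explains why these aryl groups differ.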